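The compounds below may be only part of what the source reports. "The series", "measured", "known", "first", "only" and "open" are said of these compounds alone.

Measured in an ADME assay on HUVEC cells (Homo sapiens) for cytotoxicity, read by MTT assay, with a stated time of 24 h; on this read-out lower numbers stand for higher toxicity in this test and higher numbers for lower toxicity in this test:
compound 1 `O=[N+]([O-])c1ccccc1/C=C/c1nnc(-c2ccc3c(c2)OCCO3)o1`: 323000 nM
compound 2 `Fc1cccc(/C=C/c2nnc(-c3ccc4c(c3)OCCO4)o2)c1`: 295000 nM

Compound 2 stands at 295000 nM, within the usual scatter of compound 1 at 323000 nM. Among the measured compounds shown here, these two values are the only reference points, and no step between measured compounds differing in one place is available.

The next compound is compound 3 `Cc1ccccc1/C=C/c1nnc(-c2ccc3c(c2)OCCO3)o1`, which has 2-methylphenyl in place of 3-fluorophenyl on a double-bonded chain carbon bound to a double-bonded chain carbon. For the measured compounds named here, with no measured step to calibrate this change, the working expectation in this assay is no step beyond the scatter, in either direction. The estimated 1.1-fold lower number from compound 2 to compound 3 (0.02 log units; within the scatter) reflects that expectation. Compound 3 is expected at 280000 nM, with an estimated range of 140000 nM to 560000 nM.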

Compound 3, half-maximal cytotoxic concentration: 356000 nM
Beside the measured number, compound 3's estimate is 1.3-fold (0.10 log units) below it; low and high end bracket the measured number.
By their numbers in this assay, from the lowest: compounds 2, 1 and 3 (each within the scatter of the next).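

In this assay the aryl group on a double-bonded chain carbon bound to a double-bonded chain carbon now has its first readable steps: 2-methylphenyl in place of 3-fluorophenyl gives a 1.2-fold higher number from compound 2 to compound 3 (0.08 log units; within the scatter) and methyl in place of nitro on an aromatic carbon gives a 1.1-fold higher number from compound 1 to compound 3 (0.04 log units; within the scatter). Both steps lie within the scatter, so across these three compounds only, the nitro, fluoro and methyl variants cannot be told apart in this read-out. Nothing measured alongside these values offers an explanation for this flat result.

Going by these compounds, whether an amine or a carboxylic acid on this aromatic ring, or a longer chain in its place, would give a step beyond the scatter remains open. The compounds shown also vary only this aryl group, so the contribution of the shared core to the read-out remains open too.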